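The source may report more compounds than this note shows. Statements on the series, on what has been measured and on what is new or still open speak of the compounds shown alone.

Working notes on the series. Of the compounds shown here, three have been measured in a physicochemical assay for lipophilicity, in phosphate buffer, measured as octanol-water partition, with a stated time of 24 h; on this read-out higher numbers stand for higher lipophilicity and lower numbers for lower lipophilicity. Compound 1 `O=[N+]([O-])c1ccc(Oc2ccc(/C=N/NC(=S)Nc3ccccc3)cc2)cc1` gives 4.95 in this assay. Compound 2 `S=C(N/N=C/c1ccc(Oc2ccc3ccccc3c2)cc1)Nc1ccc(Cl)cc1` gives 6.96, and compound 3 `Cc1cc(Oc2ccc(/C=N/NC(=S)Nc3ccc(Cl)cc3)cc2)ccc1Cl` gives 6.59. On these numbers compound 3 stands second highest of the three: its nearest neighbour is compound 2, which lies higher by the step of a number 0.37 log units lower from compound 2 to compound 3 (beyond the scatter), and its furthest is compound 1, which lies lower by a wide margin.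

Compound 4 `O=[N+]([O-])c1ccc(Oc2ccc(/C=N/NC(=S)Nc3ccc(Cl)cc3)cc2)cc1` has not yet been measured in this assay. It differs from compound 3 in one place: 4-nitrophenyl in place of 4-chloro-3-methylphenyl on an oxygen on an aromatic ring. For the measured compounds named here, the only measured step, a number 0.37 log units lower from compound 2 to compound 3 (beyond the scatter), concerns a different exchange on the same oxygen and only shows that exchanges at this position move the read-out by modest amounts. Compound 1 already carries the 4-nitrophenyl group and differs from compound 4 only on the other aryl ring; the value of compound 1, 4.95, therefore sets the lower region in which compound 4 should sit, while compound 3 sets the upper.

Compound 4 is therefore expected to land below compound 3, with the step of a number 0.99 log units lower from compound 3 to compound 4 (beyond the scatter) estimated. The estimate for compound 4 is 5.6, with a range from 5 to 6.2.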

Compound 4, partition coefficient: 5.52
Beside the measured number, compound 4's estimate is 0.08 log units above it, and the stated range covers the measured number.
By their numbers in this assay, from the lowest: compound 1; then compound 4; then compound 3; then compound 2.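

In this assay, for the compounds shown here, the exchange on the oxygen on an aromatic ring now reaches a large size, with a number 1.07 log units lower from compound 3 to compound 4 (beyond the scatter) and a number 1.44 log units lower from compound 2 to compound 4 (beyond the scatter) set against the modest a number 0.37 log units lower from compound 2 to compound 3 (beyond the scatter) as the only step the earlier compounds offered at this position. The other aryl ring also gets its first reading with the 4-nitrophenyl group held fixed, where chloro in place of hydrogen on an aromatic carbon gives a number 0.57 log units higher from compound 1 to compound 4 (beyond the scatter) and so a modest change, smaller than either exchange of the group on the oxygen to 4-nitrophenyl. No supporting measurement bears on why these steps take these sizes.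

The group on the oxygen is an aromatic carbon ring in every compound shown, so the read-out with a phenyl ring carrying an amine or a carboxylic acid, or with a saturated ring such as cyclohexyl, remains open. From the compounds shown here alone, the chloro step is also read only with the 4-nitrophenyl group, and its size alongside naphthalen-2-yl or 4-chloro-3-methylphenyl remains unknown.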